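A few compounds are considered here, and "the series" means these few. Any claim that something is new, unique, unknown or untested is made for them only; others in the source may bear on it.

Measured compounds:
- compound 1, `CN(C)CCN(C)c1ccc(C#N)c(CN2CCN(C(c3ccc(F)cc3)c3ccc(F)cc3)CC2)c1`, 7810 nM
- compound 2, `CN1CCCN(c2ccc(C#N)c(CN3CCN(C(c4ccc(F)cc4)c4ccc(F)cc4)CC3)c2)CC1`, 6240 nM
- compound 3, `CN(C)CCN(C)c1ccc(C(F)(F)F)c(CN2CCN(C(c3ccccc3)c3ccc(Cl)cc3)CC2)c1`, 6960 nM

All three were tested in a toxicity assay on Huh-7.5 cells (Homo sapiens) for cytotoxicity, read by MTT assay, with a stated time of 96 h; on this read-out lower numbers stand for higher toxicity in this test and higher numbers for lower toxicity in this test. Compound 1 gives 7810 nM, compound 2 gives 6240 nM, and compound 3 gives 6960 nM. Compounds 1 and 2 share a core and differ in one place: 4-methyl-1,4-diazepan-1-yl in place of (2-(dimethylamino)ethyl)(methyl)amino on an aromatic carbon. That change made the step of a 1.3-fold lower number from compound 1 to compound 2 (0.10 log units; within the scatter), so the two numbers cannot be told apart in this assay. Compound 3 stands on a different core; how the core of compound 3 differs from the core of compound 1 is not broken down here. Its value sits among the other two and within the scatter of both.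

Compound 4, `CN1CCCN(c2ccc(C(F)(F)F)c(CN3CCN(C(c4ccccc4)c4ccc(Cl)cc4)CC3)c2)CC1`, has not yet been measured in this assay . It differs from compound 3 in the same kind of change that separates compound 2 from compound 1: 4-methyl-1,4-diazepan-1-yl in place of (2-(dimethylamino)ethyl)(methyl)amino on an aromatic carbon. The surroundings are not identical, since in compound 1 the changed carbon is para to a cyano group while in compound 3 it is para to a trifluoromethyl group, so the change is the same kind rather than the same.

The expectation for compound 4 rests on one earlier example: because the same change gave a 1.3-fold lower number from compound 1 to compound 2 (0.10 log units; within the scatter), a step of about the same small size is expected from compound 3 to compound 4, a 1.2-fold lower number from compound 3 to compound 4 (0.08 log units; within the scatter). Compound 4 is therefore estimated at 5800 nM, with the likely range running from 3300 nM to 10000 nM.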

Compound 4, half-maximal cytotoxic concentration: 1290 nM
For compound 4 the middle estimate is 4.5-fold (0.65 log units) above the measured one, outside the stated range (below it).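

In this assay, placing 4-methyl-1,4-diazepan-1-yl where (2-(dimethylamino)ethyl)(methyl)amino stood on the aromatic carbon gives a 5.4-fold lower number from compound 3 to compound 4 (0.73 log units; beyond the scatter), so compound 4 is the more toxic of this pair in the test. For the compounds shown here, the same change therefore does not carry over with a fixed size between these two cores, and the step measured on one core would have been a poor guide to the step on the other: the same change on two cores in this assay, a 1.3-fold lower number (0.10 log units; within the scatter) from compound 1 to compound 2 and a 5.4-fold lower number (0.73 log units; beyond the scatter) from compound 3 to compound 4, 4.3-fold (0.63 log units) apart, beyond the scatter of two such steps This shows that the effect of the swap depends on its surroundings in this pair of cores, but with only two examples, and with cores that differ from each other in more than one place, it does not show which part of the core is responsible, nor why the gap arises.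

The compounds shown leave open whether the larger step belongs to the trifluoromethyl group or to the other parts that separate the two cores, which a pair differing from compound 3 and compound 4 in just one of those parts could settle. They also leave open how a different group in the same place, such as a simple primary amine or a longer chain ending in the same dimethylamino group, would behave on either core.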